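This account rests on a few compounds, and the source may have more. Where it says the series, first, only, none or still open, it means among the compounds named here.

Compound 1 `CCc1ccc(NC2=CC(=O)c3c(nc4n3[C@H]3OC[C@@H](O)[C@H]3OC4)C2=O)cc1` was measured in a functional assay on HeLa cells (Homo sapiens) for inhibition, read by sulforhodamine B assay (on this read-out higher numbers stand for weaker inhibition and lower numbers for stronger inhibition), where compound 1 gives 6510 nM. That is the highest of the two numbers shown, and the nearest neighbour, compound 2 `O=C1C=C(Nc2ccc(Br)cc2)C(=O)c2c1nc1n2[C@H]2OC[C@@H](O)[C@H]2OC1`, gives 3830 nM in this assay, which lies within the scatter of compound 1. Compound 3 `CCCN(CCC)C1=CC(=O)c2nc3n(c2C1=O)[C@H]1OC[C@@H](O)[C@H]1OC3` reaches only the limit of this assay, > 16000 nM. Going by the values given here, the one measured step, an at least 4.1-fold higher number from compound 2 to compound 3 (0.62 log units; beyond the scatter), swaps an arylamino group for a dialkylamino group and so does not bear on the change now followed. Compound 4 `COc1cccc(NC2=CC(=O)c3c(nc4n3[C@H]3OC[C@@H](O)[C@H]3OC4)C2=O)c1` differs from compound 1 by 3-methoxyphenyl in place of 4-ethylphenyl on an amine nitrogen. Among the compounds with values here, with no step of this aryl-to-aryl kind measured, the step of a 1.2-fold lower number from compound 1 to compound 4 (0.07 log units; within the scatter) is expected to stay within the scatter. Compound 4 is therefore estimated at 5500 nM, between 1800 nM and 16000 nM.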

Compound 4, half-maximal inhibitory concentration: > 8000 nM
Compound 4: no number, only a limit (the forecaster's own chance of this, stated with the estimate: 20%); middle value at least 1.4-fold (0.16 log units) away from the limit.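

In this assay compound 4 gives only a limit, > 8000 nM, and not a number. As far as these compounds go, this first aryl-to-aryl comparison yields an at least 1.2-fold higher number from compound 1 to compound 4 (0.08 log units; that floor lies within the scatter), so 3-methoxyphenyl in place of 4-ethylphenyl on the amine nitrogen does not bring the number down, but the true size of the step stays unknown. Whether that step goes beyond the scatter cannot be read from this floor. The compounds shown leave open how large this step really is, and whether a hydroxyl group, an amine or a longer chain on the phenyl ring would move the number beyond the scatter.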